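From thiophen-3-yl to ethynyl on a shared core

The compounds below may be only part of what the source reports. "The series", "measured", "known", "first", "only" and "open" are said of these compounds alone.

Measured in a functional assay on CCRF-CEM cells (Homo sapiens), read by MTT assay, with a stated time of 72 h; on this read-out lower numbers stand for stronger inhibition and higher numbers for weaker inhibition:
- compound 1 (`C#Cc1cn([C@@H]2O[C@H](CO)[C@@H](O)[C@H]2O)c2ncnc(OC)c12`): > 20000 nM (a limit of the assay)
- compound 2 (`CN(C)c1ncnc2c1c(-c1ccoc1)cn2[C@@H]1O[C@H](CO)[C@@H](O)[C@H]1O`): 13300 nM
- compound 3 (`CN(C)c1ncnc2c1c(-c1ccsc1)cn2[C@@H]1O[C@H](CO)[C@@H](O)[C@H]1O`): 3480 nM

Of the two results that are true numbers, the lower belongs to compound 3 , at 3480 nM. The next compound, compound 4 (`C#Cc1cn([C@@H]2O[C@H](CO)[C@@H](O)[C@H]2O)c2ncnc(N(C)C)c12`), has ethynyl in place of thiophen-3-yl on an aromatic carbon.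

Among the compounds with values here, only one measured step bears directly on this position. It swapped one ring for another and was modest: a 3.8-fold lower number from compound 2 to compound 3 (0.58 log units; beyond the scatter). Within the data shown here, it shows that the number responds to the group at this place, but no measured step replaces such a ring with ethynyl on this core, so its size is only a rough guide.

Compound 1 also carries ethynyl, and its result is a limit of the assay, > 20000 nM.

That result points towards a higher number, meaning weaker inhibition, in this assay. The expected change is a 2.9-fold higher number from compound 3 to compound 4 (0.46 log units; beyond the scatter). For compound 4 the estimated value is 10000 nM, with an expected range from 3000 nM to 20000 nM.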

Compound 4, half-maximal inhibitory concentration: 90 nM
Compound 4: middle estimate off by 110-fold (2.05 log units), on the high side; the whole stated range lies above it.
By their numbers in this assay, from the lowest: compound 4; then compound 3; then compound 2. At a limit, above all of these: compound 1.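

Ethynyl at this place gives far stronger inhibition in this assay than either ring does, with a 39-fold lower number from compound 3 to compound 4 (1.59 log units; beyond the scatter) and a 150-fold lower number from compound 2 to compound 4 (2.17 log units; beyond the scatter); both steps are much larger than the ring-for-ring step of a 3.8-fold lower number from compound 2 to compound 3 (0.58 log units; beyond the scatter), so the kind of group here matters more than that earlier step suggested. Ethynyl alone does not secure this result, however, as the two ethynyl compounds differ at a second place on the shared core, with dimethylamino in place of methoxy giving an at least 220-fold lower number from compound 1 to compound 4 (2.34 log units; beyond the scatter). Compound 1 stands at a limit of the assay rather than at a true number, so that step has no upper end: the limit of > 20000 nM in this assay, at which 1 of the 4 values shown sits.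

The compounds shown do not tell whether ethynyl itself is needed at this place or whether other small groups, such as a nitrile, a propynyl chain or a lone chlorine atom, would serve equally well. They also leave open how far the second place tolerates change, for example with a smaller amine such as methylamino or a plain amino group alongside the ethynyl.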